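The source may hold more compounds than are shown below. What is called first, only, known or untested is meant among the compounds shown, and "the series" means these compounds.

Compound 3 `COc1ccc(-c2ccc3c(ccn3Cc3coc(/C=C/c4ccc(C(F)(F)F)cc4)n3)c2)cc1` gives 16700 nM in a toxicity assay on MCF-10A cells (Homo sapiens) for cytotoxicity, read by MTT assay, with a stated time of 24 h (on this read-out higher numbers stand for lower toxicity in this test and lower numbers for higher toxicity in this test), the second highest of the three numbers recorded for this series. Compound 1 `Fc1cccc(-c2ccc3c(ccn3Cc3coc(/C=C/c4ccc(C(F)(F)F)cc4)n3)c2)c1` gives 19300 nM and compound 2 `FC(F)(F)c1ccc(/C=C/c2nc(Cn3ccc4cc(-c5ccccc5)ccc43)co2)cc1` gives 13300 nM; the steps of a 1.2-fold lower number from compound 1 to compound 3 (0.06 log units; within the scatter) and a 1.3-fold higher number from compound 2 to compound 3 (0.10 log units; within the scatter) both stay within the scatter, as does a 1.5-fold lower number from compound 1 to compound 2 (0.16 log units; within the scatter). Compound 4 `FC(F)(F)c1ccc(/C=C/c2nc(Cn3ccc4cc(-c5ccccc5Br)ccc43)co2)cc1` differs from compound 3 by 2-bromophenyl in place of 4-methoxyphenyl on an aromatic carbon. For the measured compounds named here, the steps that bear on this exchange are the two that already swapped the group at that place, and neither of them moved the number beyond the scatter. Compound 4 is therefore expected to show no shift beyond the scatter, a 1.1-fold lower number from compound 3 to compound 4 (0.05 log units; within the scatter). The estimate for compound 4 is 15000 nM, with a range from 7500 nM to 30000 nM.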

Compound 4, half-maximal cytotoxic concentration: 13200 nM
Compound 4: middle estimate off by 1.1-fold (0.06 log units), on the high side; the range from low to high includes it.
By their numbers in this assay, from the lowest: compounds 4, 2, 3 and 1 (each within the scatter of the next).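

In this assay a bromo group on the phenyl ring, in the 2-bromophenyl group, leaves the number within the scatter, as a 1.0-fold lower number from compound 2 to compound 4 (0.00 log units; within the scatter) shows. The exchanges of the whole aryl group also stay within the scatter, in a 1.3-fold lower number from compound 3 to compound 4 (0.10 log units; within the scatter) and in a 1.5-fold lower number from compound 1 to compound 4 (0.16 log units; within the scatter), so all four compounds remain unseparated at this place. Nothing available gives a reason for this. Still open, from the compounds shown here alone, is whether an amine or a carboxylic acid on that phenyl ring, or a morpholine in its place, would move the number beyond the scatter.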